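Sulfonylbenzylamides: swapping the group on the carbonyl carbon

The source may hold more compounds than are shown below. What is called first, only, known or untested is meant among the compounds shown, and "the series" means these compounds.

Three compounds of the series have numbers in an assay for inhibition of Nicotinamide phosphoribosyltransferase (Homo sapiens), read by mass spectrometry, with stated times of 15 min and 30 min; on this read-out higher numbers stand for weaker inhibition and lower numbers for stronger inhibition. Compound 1 `O=C(NCc1ccc(S(=O)(=O)c2ccc(F)c(F)c2)cc1)c1cc2cnccc2[nH]1` gives 10 nM, compound 3 `O=C(NCc1ccc(S(=O)(=O)c2cccc(C(F)(F)F)c2)cc1)c1cnc2nccn2c1` gives 1 nM, and compound 2 `O=C(NCc1ccc(S(=O)(=O)c2ccccc2)cc1)c1ccc2nncn2c1` gives 370 nM. Among the measured compounds shown here, compound 2 thus stands highest of the three, beyond the scatter from both compound 1 and compound 3; however, compound 1 and compound 3 also carry different substituents on the sulfonyl-bearing ring, so no single step between measured compounds is isolated.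

Compound 4 `O=C(NCc1ccc(S(=O)(=O)c2ccccc2)cc1)c1nc2ccncc2s1` differs from compound 2 only on the carbonyl carbon: a group of 9 heavy atoms (6 carbon, 2 nitrogen, 1 sulfur; one five-membered aromatic ring with 2 hetero atoms, one six-membered aromatic ring with 1 hetero atom) in place of a group of 9 heavy atoms (6 carbon, 3 nitrogen; one five-membered aromatic ring with 3 hetero atoms, one six-membered aromatic ring with 1 hetero atom), on a carbonyl carbon

Since the two other groups on the carbonyl carbon in compound 1 and compound 3 both go with much lower numbers than compound 2 gives in this assay, a step toward a lower number is expected for compound 4, but with wide uncertainty given the confounded comparisons. The expected step from compound 2 to compound 4 is a 2.5-fold lower number from compound 2 to compound 4 (0.39 log units; beyond the scatter). Compound 4 is estimated at 150 nM, within a range of 30 nM to 800 nM.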

Compound 4, half-maximal inhibitory concentration: 210 nM
Beside the measured number, compound 4's estimate is 1.4-fold (0.15 log units) below it; the measured number falls inside the stated range.
By their numbers in this assay, from the lowest: compound 3; then compound 1; then compounds 4 and 2 (each within the scatter of the next).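

Among the compounds shown here, this is the first step that isolates the group on the carbonyl carbon: in this assay, the exchange gives a 1.8-fold lower number from compound 2 to compound 4 (0.25 log units; within the scatter) and does not separate the two groups. On a carbonyl carbon whose other neighbour is an amide-type nitrogen, a five-membered aromatic ring with 2 hetero atoms, sulfur among them, thus reads the same as one with 3 hetero atoms, with the hydrogen-bond donor and acceptor counts unchanged. No measured property is available to bear on this result.

Still open, from the compounds shown here alone, is how much of the lower numbers of compound 1 and compound 3 belongs to the group on the carbonyl carbon and how much to the substituents on the sulfonyl-bearing ring, as both differ from compound 2 and compound 4 in both places. Also open, going by these compounds, is how a morpholine or a short alkyl chain would read on the carbonyl carbon.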